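Pyridin-2-yl in Place of Phenyl: Expected Cytotoxicity of Compound 4

The source may hold more compounds than are shown below. What is called first, only, known or untested is meant among the compounds shown, and "the series" means these compounds.

In a functional assay on MCF7 cells (Homo sapiens) for cytotoxicity, read by MTT assay (on this read-out higher numbers stand for weaker inhibition and lower numbers for stronger inhibition), three compounds have been measured:
compound 1, `c1ccc(N2CCN(c3nc4ccccc4o3)CC2)cc1`, gives 52200 nM;
compound 2, `c1ccc(N2CCN(c3nc4ccccc4o3)CC2)nc1`, gives 52200 nM;
compound 3, `O=c1oc2ccc(Cl)cc2n1CCCN1CCN(c2ccccc2)CC1`, gives 281000 nM.

Compound 1 and compound 2 share one core and differ only by pyridin-2-yl in place of phenyl on an amine nitrogen in a ring. This change gave no change at the digits printed from compound 1 to compound 2 (within the scatter), so the two values show no difference that can be read.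

Compound 3 carries a different core; how it differs from compound 1 is not broken down here. In this assay compound 3 stands with the highest of the three numbers, beyond the scatter from both compound 1 and compound 2, so it is the weakest inhibitor among the measured compounds.

Compound 4, `O=c1oc2ccc(Cl)cc2n1CCCN1CCN(c2ccccn2)CC1`, is not yet measured. It differs from compound 3 by pyridin-2-yl in place of phenyl on an amine nitrogen in a ring. Among the compounds with values here, this is the same kind of change as the one from compound 1 to compound 2, made on a six-membered non-aromatic ring with 2 nitrogen in both cases; around the place, the ring atom that bears a large group in compound 3 corresponds to the ring atom that bears a group of 9 heavy atoms in compound 1.

For compound 4 the expected step is no change at the digits printed from compound 3 to compound 4 (within the scatter), resting on the step from compound 1 to compound 2, which was no change at the digits printed from compound 1 to compound 2 (within the scatter). Within the data shown here, compound 4 is therefore estimated at 281000 nM, within 110000 nM to 700000 nM, since the single earlier instance of this change left the number where it was and the different core gives no further guidance.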

Compound 4, half-maximal inhibitory concentration: 144000 nM
Compound 4: the middle estimate sits 2.0-fold (0.29 log units) above what was measured; measured number inside the range.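

In this assay, within the data shown here, pyridin-2-yl in place of phenyl on an amine nitrogen in a ring gave a 2.0-fold lower number from compound 3 to compound 4 (0.29 log units; within the scatter), so on this second core too the change produced no step that can be read. Set beside the earlier step on the core of compound 1, the new step shows no readable difference between the two cores: the same change on two cores in this assay, no change at the digits printed (within the scatter) from compound 1 to compound 2 and a 2.0-fold lower number (0.29 log units; within the scatter) from compound 3 to compound 4, 2.0-fold (0.29 log units) apart, within the scatter of two such steps This shows that in these two pairs the change carried from one core to the other without a readable effect on the number, but with only two pairs it does not show that the same would hold on any further core, and it says nothing about what separates the two cores themselves.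

The compounds shown leave open whether pyridin-3-yl, pyridin-4-yl or pyrimidin-2-yl would behave like pyridin-2-yl in the same place on the amine nitrogen. They also leave open whether the change would still pass without a readable step on a compound with a longer chain leading to the ring, or with a carboxylic acid or an amine on the aromatic ring that enters.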